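The source may report more compounds than this note shows. Statements on the series, on what has been measured and on what is new or still open speak of the compounds shown alone.

Measured so far:
Compound 1, `CC(c1cc(F)c2ncccc2c1)n1cnc2ncc(-c3cnn(C)c3)nc21`: > 10000 nM
Compound 2, `Cn1cc(-c2cnc3nc(O)n(Cc4ccc5ncccc5c4)c3n2)cn1`: > 10000 nM

Both results come from a functional assay on NCI-H1993 cells (Homo sapiens) for inhibition, read by CCK-8 assay, with a stated time of 72 h; on this read-out lower numbers stand for stronger inhibition and higher numbers for weaker inhibition. For compound 1 the value > 10000 nM is a limit of the assay, not a number. For compound 2 the value > 10000 nM is likewise a limit. Among the compounds with values here, compound 1 therefore stands at the top of what has been measured, at the limit of > 10000 nM in this assay, at which 2 of the 2 values shown sit, and no step between measured compounds can be drawn from these two results, so nothing yet shows how a change at this position moves the read-out. Compound 3, `CC(c1cc(F)c2ncccc2c1)n1cnc2ncc(-c3cnc4ccccc4c3)nc21`, differs from compound 1 by quinolin-3-yl in place of 1-methyl-1H-pyrazol-4-yl on an aromatic carbon. Within the data shown here, with no measured step to lean on, the step of an at least 3.3-fold lower number from compound 1 to compound 3 (0.52 log units; beyond the scatter) is expected to go toward stronger inhibition, but with little certainty. Compound 3 is expected to give about 3000 nM in this assay, between 300 nM and 20000 nM, with a real chance of again only a limit.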

Compound 3, half-maximal inhibitory concentration: > 10000 nM
Compound 3 was reported as a limit (the forecaster's own chance of this, stated with the estimate: 45%); middle value at least 3.3-fold (0.52 log units) from the limit.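

Compound 3 gives > 10000 nM, which is a limit of the assay and not a number. Within the data shown here, compound 1 also sits at a limit, so no step from compound 1 to compound 3 can be read. The compounds shown leave open which change, if any, would bring a measurable number, since all remain at one ceiling: the limit of > 10000 nM in this assay, at which 3 of the 3 values shown sit.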